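Hydroxy for cyano on the hydrazone aryl ring

The source may hold more compounds than are shown below. What is called first, only, known or untested is meant among the compounds shown, and "the series" means these compounds.

Measured so far in a functional assay on PC-3 cells (Homo sapiens) for cytotoxicity, read by MTT assay, with a stated time of 72 h; a higher number here means a weaker inhibitor, a lower number a stronger inhibitor:
compound 1 `N#Cc1ccc(/C=N/NC(=O)Nc2cc3c(Nc4ccc(F)c(Cl)c4)ncnc3cc2O[C@H]2CCOC2)cc1` gives 28100 nM
compound 2 `O=C(N/N=C/c1ccc(O)cc1O)Nc1cc2c(Nc3ccc(F)c(Cl)c3)ncnc2cc1O[C@H]1CCOC1` gives 7540 nM

For the measured compounds named here, compound 1 stands highest of the two numbers; the nearest is compound 2, reached by the step of a 3.7-fold lower number from compound 1 to compound 2 (0.57 log units; beyond the scatter), which is the only step bearing on the question. Going by the values given here, compound 3 `O=C(N/N=C/c1ccc(O)cc1)Nc1cc2c(Nc3ccc(F)c(Cl)c3)ncnc2cc1O[C@H]1CCOC1` differs from compound 1 by hydroxy in place of cyano on an aromatic carbon, a smaller change than the one leading to compound 2. For compound 3 a lower number is therefore expected in this assay, of a size near or somewhat under that step, a 2.6-fold lower number from compound 1 to compound 3 (0.41 log units; beyond the scatter), giving an estimated 11000 nM with a range from 4500 nM to 28000 nM.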

Compound 3, half-maximal inhibitory concentration: 4890 nM
Estimate against measurement, compound 3: 2.2-fold (0.35 log units) above; measured number inside the range.
By their numbers in this assay, from the lowest: compounds 3 and 2 (each within the scatter of the next); then compound 1.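

In this assay, hydroxy on the aromatic carbon para to a large group, with no other change to the 4-cyanophenyl of compound 1, is enough for a 5.7-fold lower number from compound 1 to compound 3 (0.76 log units; beyond the scatter). The further hydroxy of the 2,4-dihydroxyphenyl group is not separated from the 4-hydroxyphenyl group, with a 1.5-fold lower number from compound 2 to compound 3 (0.19 log units; within the scatter) lying within the scatter. No measurement available here explains either step. Still open, from the compounds shown here alone, is how an amine, a methoxy group or a carboxylic acid on this same aromatic carbon would compare with hydroxy. Also open, going by these compounds, is what an unsubstituted phenyl would give.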